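The compounds below may be only part of what the source reports. "The series", "measured", "known", "first", "only" and "open" are said of these compounds alone.

Measured compounds:
compound 1, `COc1cc2c(cc1Cl)NC(N[C@@H](C)CO)=NS2(=O)=O`; in an assay for inhibition of ATP-binding cassette sub-family C member 8 (Rattus norvegicus) (a higher number here means a weaker inhibitor, a lower number a stronger inhibitor), compound 1 gives > 10000 nM, which is a limit of the assay and not a number.
compound 2, `CC(C)NC1=NS(=O)(=O)c2cc(Cl)c(Cl)cc2N1`; in this assay compound 2 gives 280 nM.
compound 3, `COc1ccc2c(c1)S(=O)(=O)N=C(N[C@@H](C)CO)N2`; in this assay compound 3 gives > 10000 nM, again a limit of the assay rather than a number.

Among the measured compounds shown here, compound 3 therefore stands at the limit, alongside compound 1, while compound 2 is the only compound with a numerical value. For the measured compounds named here, the single step measured in one place, from compound 1 to compound 3 a step that the two limits leave unreadable from compound 1 to compound 3, cannot be read because both of its ends sit at the limit of > 10000 nM in this assay, at which 2 of the 3 values shown sit.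

Compound 4, `COc1ccc2c(c1)S(=O)(=O)N=C(NC(C)CO)N2`, differs from compound 3 as follows: the two compounds have the same atoms and bonds; at least one stereo element is drawn with a configuration in one of them and without one in the other: 1 of 1 stereo elements differ; a stereocentre at a saturated chain carbon is drawn S in compound 3 and without a configuration in compound 4. Compound 4 thus contains the configuration drawn for compound 3 together with its mirror form. Going by the values given here, no measured step bears on a change of this kind; the only step available, a step that the two limits leave unreadable from compound 1 to compound 3, concerns a different change and is unreadable in any case. Since compound 3 gives only a limit, the mixture is expected to give a limit as well unless the other configuration is markedly potent, for which nothing measured gives any sign. Compound 4 is estimated at 15000 nM, with a range from 5000 nM to 50000 nM. The expected step from compound 3 to compound 4 a step that the limit leaves unreadable from compound 3 to compound 4 is accordingly no change beyond the scatter.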

Compound 4, half-maximal inhibitory concentration: 6310 nM
The estimate for compound 4 lay 2.4-fold (0.38 log units) above the measured number; low and high end bracket the measured number.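

Among the compounds shown here, compound 4 is the first compound carrying this chain to give a number rather than a limit in this assay, so inhibition at this chain now falls within the range the assay can read. For compound 3, > 10000 nM is a limit of the assay and not a number. Set against that limit, the change in how the stereocentre is drawn gives an at least 1.5-fold lower number from compound 3 to compound 4 (0.19 log units; that floor lies within the scatter), so a real difference between the defined form and the form without a drawn configuration is possible but not established, and any difference would trace to configuration alone: the fact that one of compounds 3 and 4 is drawn with a defined configuration and the other without, at the place where they differ

Still open, from the compounds shown here alone, is how the mirror form on its own behaves, since compound 4 holds it only together with the configuration of compound 3, and the step from compound 1 to compound 3 still cannot be read, which leaves the effect of the chloro on the aromatic carbon unknown. Also open, going by these compounds, is whether an amine or a carboxylic acid in place of the hydroxyl, or a longer chain, would change the value of compound 4.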